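Ring Closure of a Chain Amine on Two Cores

The compounds below may be only part of what the source reports. "The series", "measured", "known", "first", "only" and "open" are said of these compounds alone.

Compound 1 `CCN(CC)C/C=C/C(=O)Nc1cc2c(N3CCc4ccccc43)ncnc2cc1O[C@@H]1CCOC1` and compound 2 `O=C(/C=C/CN1CCCC1)Nc1cc2c(N3CCc4ccccc43)ncnc2cc1O[C@@H]1CCOC1` are built on one core, while compound 3 `CCN(CC)C/C=C/C(=O)Nc1cc2c(N3CCCc4ccccc43)ncnc2cc1OC` and compound 4 `COc1cc2ncnc(N3CCCc4ccccc43)c2cc1NC(=O)/C=C/CN1CCCC1` are built on another; the difference between the two cores is not broken down here. In a functional assay on PC-3 cells (Homo sapiens) for antiproliferative activity, read by MTT assay, with a stated time of 72 h (a higher number here means a weaker inhibitor, a lower number a stronger inhibitor), compound 1 gives 5780 nM, compound 2 gives 1510 nM and compound 3 gives 6890 nM. The change pyrrolidin-1-yl in place of diethylamino on a saturated chain carbon bound to a double-bonded chain carbon brought a 3.8-fold lower number from compound 1 to compound 2 (0.58 log units; beyond the scatter). The same change, (pyrrolidin-1-yl in place of diethylamino on a saturated chain carbon bound to a double-bonded chain carbon), carries compound 3 to compound 4, which has not yet been measured in this assay. For the measured compounds named here, the writer expects the step to be a 3.4-fold lower number from compound 3 to compound 4 (0.54 log units; beyond the scatter), resting on a 3.8-fold lower number from compound 1 to compound 2 (0.58 log units; beyond the scatter) as the one precedent for this change. Compound 4 is accordingly estimated at 2000 nM, with a likely range from 800 nM to 5000 nM.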

Compound 4, half-maximal inhibitory concentration: 1740 nM
For compound 4 the middle estimate is 1.1-fold (0.06 log units) above the measured one; the range from low to high includes it.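

In this assay, pyrrolidin-1-yl in place of diethylamino on a saturated chain carbon bound to a double-bonded chain carbon brought a 4.0-fold lower number from compound 3 to compound 4 (0.60 log units; beyond the scatter) on the core of compound 3. The step on this core matches the one on the core of compound 1: the same change on two cores in this assay, a 3.8-fold lower number (0.58 log units; beyond the scatter) from compound 1 to compound 2 and a 4.0-fold lower number (0.60 log units; beyond the scatter) from compound 3 to compound 4, 1.0-fold (0.01 log units) apart, within the scatter of two such steps. So in this assay the change carried from one core to the other with its size kept, but two pairs do not show that it would hold on any further core or in any other assay, and they do not show why the number falls.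

The compounds shown leave open how other chain amines, such as piperidin-1-yl, morpholin-4-yl or dimethylamino, would behave in this place. They also leave open what a longer chain leading to the amine would do.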